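A few compounds are considered here, and "the series" means these few. Any claim that something is new, unique, unknown or untested is made for them only; others in the source may bear on it.

Measured so far:
Compound 1 `O=c1c(Cc2coc3cccc(OCC4CCCCC4)c3c2=O)coc2cc(O)ccc12` — 4250 nM
Compound 2 `CC(C)CCOc1cccc2occ(Cc3coc4ccccc4c3=O)c(=O)c12` — a limit of the assay, > 10000 nM

Of the compounds shown here, two have been tested in a functional assay on PC-3 cells (Homo sapiens) for antiproliferative activity, read by XTT assay; a higher number here means a weaker inhibitor, a lower number a stronger inhibitor. Compound 1, `O=c1c(Cc2coc3cccc(OCC4CCCCC4)c3c2=O)coc2cc(O)ccc12`, gives 4250 nM in this assay. Compound 2, `CC(C)CCOc1cccc2occ(Cc3coc4ccccc4c3=O)c(=O)c12`, returns only a limit of the assay, > 10000 nM. Compound 2 thus sits at the limit of > 10000 nM in this assay, at which 1 of the 2 values shown sits. Of the two numbers shown, compound 2 stands at the weak end, with no exact value known for it; compound 1 has a measured number and compound 2 does not.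

The next compound, compound 3, `CC(C)COc1cccc2occ(Cc3coc4ccccc4c3=O)c(=O)c12`, has not yet been measured in this assay. It differs from compound 2 in one place: isopropyl in place of isobutyl on a saturated chain carbon bound to an oxygen on an aromatic ring. For the measured compounds named here, no step between measured compounds is available to set the expectation, so the estimate rests on compound 2 alone. A small change at this chain is expected to move the value little, most likely not beyond the usual scatter. The expected step, a step that the limit leaves unreadable from compound 2 to compound 3, is therefore estimated to be close to none. Compound 3 is expected to give 15000 nM, with a range from 5000 nM to 50000 nM, and it may well return only a limit again.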

Compound 3, half-maximal inhibitory concentration: 1720 nM
Estimate against measurement, compound 3: 8.7-fold (0.94 log units) above; the measured number lies below the stated range.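

In this assay, the chain on the saturated carbon bound to the aromatic oxygen proves to be a sensitive place: with isopropyl in place of isobutyl, which can also be read as isobutoxy in place of isopentyloxy, the data show an at least 5.8-fold lower number from compound 2 to compound 3 (0.76 log units; beyond the scatter). Compound 2 gives only a limit of the assay, > 10000 nM, so this pair now shows that a small trim of the chain can carry activity from beyond the reach of the assay to a measured value. The step is only a lower bound on the change, and its true size stays unknown because compound 2 has no exact value: the limit of > 10000 nM in this assay, at which 1 of the 3 values shown sits.

A single pair cannot show whether activity would keep changing in the same direction with a still shorter chain, such as ethoxy or methoxy, or whether a branched group is needed at all, as a straight butoxy chain might tell. It also leaves open how this position would respond to an amine or a carboxylic acid at the end of the chain, and whether such a group would be tolerated in this assay.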